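Ortho-Methyl on the Terminal Phenyl: Expected Effect on Cytotoxicity

A few compounds are considered here, and "the series" means these few. Any claim that something is new, unique, unknown or untested is made for them only; others in the source may bear on it.

Measured compounds:
Compound 1, `COc1cc2c(Oc3ccc(NC(=O)c4cc(-c5ccccc5)ccn4)cc3F)ccnc2cc1OCCCN1CCN(C)CC1`, gives 91 nM in a functional assay on NCI-H460 cells (Homo sapiens) for cytotoxicity, read by MTT assay, with a stated time of 72 h; a higher number here means a weaker inhibitor, a lower number a stronger inhibitor.
Compound 2, `COc1cc2c(Oc3ccc(NC(=O)c4cc(-c5ccccc5F)ccn4)cc3F)ccnc2cc1OCCCN1CCCCC1`, gives 130 nM in this assay.

Compound 1 has the lower of the two numbers, but its value and that of compound 2 lie within the usual scatter of each other, so neither can be set above the other. Compound 3, `COc1cc2c(Oc3ccc(NC(=O)c4cc(-c5ccccc5C)ccn4)cc3F)ccnc2cc1OCCCN1CCN(C)CC1`, differs from compound 1 in one place: methyl in place of hydrogen on an aromatic carbon. For the measured compounds named here, no pair of measured compounds separated by exactly this change exists, so the size of the step has no precedent here. The expected step from compound 1 to compound 3 is estimated to be small, with no clear direction beyond the scatter, as a 1.3-fold higher number from compound 1 to compound 3 (0.12 log units; within the scatter). Compound 3 is therefore expected to come in near 120 nM, estimated to fall between 50 nM and 300 nM in this assay.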

Compound 3, half-maximal inhibitory concentration: 150 nM
Estimate against measurement, compound 3: 1.3-fold (0.10 log units) below; measured number inside the range.
By their numbers in this assay, from the lowest: compounds 1, 2 and 3 (each within the scatter of the next).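

For the compounds shown here, the change from phenyl to 2-methylphenyl now has a measured size: in this assay it gives a 1.6-fold higher number from compound 1 to compound 3 (0.22 log units; within the scatter), and this is the only step measured at this position. A methyl on this aromatic carbon, ortho to a large group, therefore leaves the number in a range that cannot be told apart from that of the unsubstituted phenyl. No measurement at hand bears on why the step is this size.

The compounds shown leave open whether a larger or different group at this same place, such as methoxy, an amine or a carboxylic acid, would produce a step beyond the scatter. Going by these compounds alone, they also leave open whether the methyl step would stay the same size on other members, since this single pair is its only example.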